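Ethoxy in Place of Methoxy on the Shared Core

This account rests on a few compounds, and the source may have more. Where it says the series, first, only, none or still open, it means among the compounds named here.

The study concerns two measured compounds and one awaiting measurement, all built on the same core. Compound 1 `CCOc1cc(/C=C/C(=O)c2ccncc2)cc(OC)c1OCC` carries two ethoxy groups and one methoxy, and in an assay on cell membranes for inhibition of cytochrome P450 1A1 (Homo sapiens), read by fluorescence, using microsomes, with a stated time of 10 min (on this read-out lower numbers stand for stronger inhibition and higher numbers for weaker inhibition), compound 1 gives 65 nM. Compound 2 `COc1cc(/C=C/C(=O)c2ccncc2)cc(OC)c1OC` carries three methoxy groups, and in this assay compound 2 gives 61 nM. Compound 2 stands alongside compound 1 on the numbers shown: the two values lie within the scatter of each other, so neither can be ranked against the other.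

Compound 3 `CCOc1c(OC)cc(/C=C/C(=O)c2ccncc2)cc1OC` differs from compound 2 by methyl in place of hydrogen on a saturated chain carbon bound to an oxygen on an aromatic ring, that is, methoxy to ethoxy. Given that compound 1 at 65 nM and compound 2 at 61 nM are indistinguishable, a step from compound 2 to compound 3 of a 1.0-fold higher number from compound 2 to compound 3 (0.01 log units; within the scatter) in this assay is expected, nothing beyond the scatter in either direction. Compound 3 is therefore estimated at 62 nM, within 30 nM to 125 nM.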

Compound 3, half-maximal inhibitory concentration: 230 nM
Estimate against measurement, compound 3: 3.7-fold (0.57 log units) below; measured number outside the range, above it.
By their numbers in this assay, from the lowest: compounds 2 and 1 (each within the scatter of the next); then compound 3.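

In this assay the change from methoxy to ethoxy is not silent: methyl in place of hydrogen gives a 3.8-fold higher number from compound 2 to compound 3 (0.58 log units; beyond the scatter) and so weakens inhibition. The opposite kind of change, hydrogen in place of methyl, moves the read-out the same way, with a 3.5-fold higher number from compound 1 to compound 3 (0.55 log units; beyond the scatter) as its result. Adding a methyl and removing one therefore both raise the number, so a count of ethoxy groups does not order these three compounds, and what a methyl does here depends on which oxygen carries it and on what the other oxygens carry. Nothing shown here gives a reason for this result. The compounds shown leave open whether a longer chain such as propoxy would raise the number further, and how a free hydroxy group on the same ring would read.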